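Swapping Hydroxy for (3-Chlorophenyl)amino on Compound 1

The source may report more compounds than this note shows. Statements on the series, on what has been measured and on what is new or still open speak of the compounds shown alone.

In a functional assay on NCI-H460 cells (Homo sapiens) for inhibition, read by MTT assay, with a stated time of 24 h, tested at 100 ug/mL (on this read-out lower numbers stand for less inhibition of growth and higher numbers for more inhibition of growth at the one concentration tested), compound 1 (`O=C(O)CCCCC(CCSC(=O)c1ccccc1)SC(=O)c1ccccc1`) gives 72.8%, the highest of the three numbers in hand. Compound 3 (`O=C(CCCCC(S)CCS)Nc1ccc(Br)cn1`) gives 55.9% and compound 2 (`COc1ccc(NC(=O)CCCCC(S)CCS)cc1`) gives 23.5%, both lower than compound 1 by more than the scatter. Compound 4 (`O=C(CCCCC(CCSC(=O)c1ccccc1)SC(=O)c1ccccc1)Nc1cccc(Cl)c1`) keeps the core of compound 1 but has (3-chlorophenyl)amino in place of hydroxy on a carbonyl carbon. Going by the values given here, no measured pair isolates this change. Compounds 2 and 3 also have a ring-bearing amino group on that carbonyl carbon, but differ from compound 1 elsewhere, so they offer only a loose guide. A downward move beyond the scatter is expected, an estimated a number 17.8 percentage points lower from compound 1 to compound 4 (beyond the scatter). Compound 4 is estimated at 55%, with an expected range of 30% to 78%.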

Compound 4, percent growth inhibition at one concentration: "not active" (no number reported)
Compound 4 has no reported number here; there is nothing to compare the estimate with.
By their numbers in this assay, from the lowest: compound 2; then compound 3; then compound 1.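

Going by these compounds alone, compound 4 is reported as "not active" with no number, so no step from compound 1 can be read. Nothing available accounts for this result. In this assay, the compounds shown leave open what (3-chlorophenyl)amino in place of hydroxy does on its own.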